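Swapping phenyl for furan-2-yl on the dihydropyrazole core

This account rests on a few compounds, and the source may have more. Where it says the series, first, only, none or still open, it means among the compounds named here.

Measured so far:
- compound 1, `CC(=O)N1N=C(c2ccccc2)CC1c1ccc(N(C)C)cc1`: 7880 nM
- compound 2, `CC(=O)N1N=C(c2ccco2)CC1c1cccc([N+](=O)[O-])c1`: 20000 nM

In a functional assay on PC-3 cells (Homo sapiens) for cytotoxicity, read by sulforhodamine B assay, with a stated time of 48 h (a lower number here means a stronger inhibitor, a higher number a weaker inhibitor), compound 1 gives the lowest of the two numbers; compound 2, which carries a furan-2-yl ring and a nitro-substituted phenyl on the shared core, gives a number that is higher and beyond the scatter. Compound 3, `CC(=O)N1N=C(c2ccco2)CC1c1ccc(N(C)C)cc1`, keeps the dimethylamino-substituted phenyl of compound 1 and differs from it in one place: furan-2-yl in place of phenyl on a carbon with a double bond to nitrogen. Within the data shown here, no measured pair isolates this exchange, so the direction rests on the two values alone. Among the measured compounds shown here, since the only compound bearing a furan-2-yl ring, compound 2, sits at 20000 nM, a modest weakening from compound 1 to compound 3 is expected, a 1.5-fold higher number from compound 1 to compound 3 (0.18 log units; within the scatter), a step that may still fall within the scatter. Compound 3 is estimated at 12000 nM, with a plausible range from 4000 nM to 40000 nM in this assay.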

Compound 3, half-maximal inhibitory concentration: 16700 nM
Beside the measured number, compound 3's estimate is 1.4-fold (0.14 log units) below it; measured number inside the range.
By their numbers in this assay, from the lowest: compound 1; then compounds 3 and 2 (each within the scatter of the next).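

In this assay, the exchange of phenyl for furan-2-yl on a carbon with a double bond to nitrogen now has a measured pair of its own, showing a 2.1-fold higher number from compound 1 to compound 3 (0.33 log units; beyond the scatter), a modest step. With the dimethylamino-substituted phenyl held fixed, phenyl at this position gives the lower number, so furan-2-yl is no gain over it in this assay. Nothing measured here accounts for the step, and the data cannot say what about the exchange produces it.

The compounds shown leave open how a thiophene ring, a pyridine ring or a fluorine-bearing phenyl would behave at this position. They also leave open whether the same exchange gives a step of similar size when the nitro-substituted phenyl of compound 2 stands on the shared core.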